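The compounds below may be only part of what the source reports. "The series", "measured", "known", "first", "only" and "open" are said of these compounds alone.

Within the data shown here, compound 3 `O=C1C=C(Nc2ccccc2F)C(=O)c2c1nc1n2[C@H]2OC[C@@H](O)[C@H]2OC1` is one of three compounds measured in a functional assay on ECa-109 cells for inhibition, with ECa-109 cell line (Homo sapiens) as the target, read by sulforhodamine B assay; a higher number here means a weaker inhibitor, a lower number a stronger inhibitor; in that test compound 3 gives 2760 nM. Its nearest neighbour is compound 1 `O=C1C(Nc2ccccc2F)=CC(=O)c2c1nc1n2[C@H]2OC[C@@H](O)[C@H]2OC1`, which in this assay gives 2660 nM, while compound 2 `O=C1C(Nc2ccccc2)=CC(=O)c2c1nc1n2[C@H]2OC[C@@H](O)[C@H]2OC1` gives 3560 nM and is the furthest away; both gaps fall within the scatter, so the three numbers cannot be told apart. Compound 4 `O=C1C=C(Nc2ccccc2)C(=O)c2c1nc1n2[C@H]2OC[C@@H](O)[C@H]2OC1` differs from compound 3 by hydrogen in place of fluoro on an aromatic carbon. Among the measured compounds shown here, the one measured step of this kind is a 1.3-fold higher number from compound 1 to compound 2 (0.13 log units; within the scatter), which stayed within the scatter. The same outcome is expected here. Compound 4 is therefore expected to give 3400 nM in this assay, with a likely range of 1700 nM to 6800 nM. The step this expectation means is a 1.2-fold higher number from compound 3 to compound 4 (0.09 log units; within the scatter).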

Compound 4, half-maximal inhibitory concentration: 4970 nM
Compound 4: the middle estimate sits 1.5-fold (0.16 log units) below what was measured; measured number inside the range.
By their numbers in this assay, from the lowest: compounds 1, 3, 2 and 4 (each within the scatter of the next).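

Swapping fluoro for hydrogen now has a second reading on another core: in this assay, the change gives a 1.8-fold higher number from compound 3 to compound 4 (0.26 log units; within the scatter). On neither core does going from (2-fluorophenyl)amino to anilino give a step that stands clear of the noise, and the two readings agree with each other: the same change on two cores in this assay, a 1.3-fold higher number (0.13 log units; within the scatter) from compound 1 to compound 2 and a 1.8-fold higher number (0.26 log units; within the scatter) from compound 3 to compound 4, 1.3-fold (0.13 log units) apart, within the scatter of two such steps

Still open, from the compounds shown here alone, is whether a different group at this place on the ring, such as a methoxy group, an amine or a carboxylic acid, would shift the number beyond the scatter. Only fluoro and hydrogen are compared here, so how much this position matters remains unsettled.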